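The source may hold more compounds than are shown below. What is called first, only, known or untested is meant among the compounds shown, and "the series" means these compounds.

Three compounds of one series have so far been run in a functional assay on A-375 cells (Homo sapiens) for cytotoxicity, read by MTT assay; on this read-out lower numbers stand for stronger inhibition and higher numbers for weaker inhibition. Compound 1 `O=C(NCCNc1nccc(-c2c(-c3cccc(F)c3)nc3sccn23)n1)c1c(F)cccc1F` gives 2700 nM. Compound 2 `COc1ccc(S(=O)(=O)NCCCNc2nccc(-c3c(-c4cccc(F)c4)nc4sccn34)n2)cc1` gives 5510 nM. Compound 3 `O=S(=O)(NCCNc1nccc(-c2c(-c3cccc(F)c3)nc3sccn23)n1)c1ccc(Cl)cc1` gives 18600 nM, the highest of the three numbers; compound 2 stands nearest to it and compound 1 furthest. Going by the values given here, the single step measured within the set runs a 6.9-fold higher number from compound 1 to compound 3 (0.84 log units; beyond the scatter), with (4-chlorophenyl)sulfonyl in place of (2,6-difluorophenyl)carbonyl on an amine nitrogen. Compound 2 differs from compound 3 in more than one place, so its lower number is not read as a step.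

Compound 4 `O=S(=O)(NCCNc1nccc(-c2c(-c3cccc(F)c3)nc3sccn23)n1)c1ccccc1` is not yet measured. It differs from compound 3 by hydrogen in place of chloro on an aromatic carbon. Among the compounds with values here, no measured step touches this chloro: the step from compound 1 to compound 3 exchanges the whole group on the amine nitrogen, and compound 2 is separated from compound 3 by more than one change. Within the data shown here, there is thus no step that bears directly on the change, and only its small size guides the expectation. The expected step is a 1.2-fold lower number from compound 3 to compound 4 (0.09 log units; within the scatter), most likely within the scatter, with no direction favoured. Compound 4 is therefore estimated at 15000 nM, with a range from 6000 nM to 40000 nM.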

Compound 4, half-maximal inhibitory concentration: 11000 nM
Estimate against measurement, compound 4: 1.4-fold (0.13 log units) above; the range from low to high includes it.
By their numbers in this assay, from the lowest: compound 1; then compounds 2, 4 and 3 (each within the scatter of the next, the first and the last beyond it).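

Working in this assay, hydrogen in place of chloro on the aromatic carbon para to a large group gives the first reading at this position, a 1.7-fold lower number from compound 3 to compound 4 (0.23 log units; within the scatter) and the chloro therefore adds no step beyond the scatter here. The exchange on the amine nitrogen can now be read with and without the chloro, as a 6.9-fold higher number from compound 1 to compound 3 (0.84 log units; beyond the scatter) and as a 4.1-fold higher number from compound 1 to compound 4 (0.61 log units; beyond the scatter) and both lie beyond the scatter, so among these compounds the gap to compound 1 does not rest on the chloro. No measurement on hand bears on the reason for either step.

In both steps from compound 1, the carbonyl and the 2,6-difluoro pattern change together, so their shares stay unresolved; a (2,6-difluorophenyl)sulfonyl or a benzoyl partner would separate them. Also open, on these data alone, are how a methoxy, an amine or a carboxylic acid would read at the position of the chloro, and what a longer chain does on its own, as compound 2 differs from compound 4 in more than one place.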